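One change on the sulfur-bound benzyl group

The source may report more compounds than this note shows. Statements on the series, on what has been measured and on what is new or still open speak of the compounds shown alone.

Measured so far:
compound 1, `Cc1ccc(CSc2cc(Cl)c(C)cc2S(=O)(=O)/N=C(\N)n2nc(C)cc2-c2ccccc2)cc1`: 28000 nM
compound 2, `Cc1ccc(CSc2cc(Cl)c(C)cc2S(=O)(=O)/N=C(\N)n2nccc2-c2ccccc2)cc1`: 14000 nM

In a functional assay on HCT-116 cells (Homo sapiens) for cytotoxicity, read by MTT assay, with a stated time of 72 h (a higher number here means a weaker inhibitor, a lower number a stronger inhibitor), compound 1 gives 28000 nM, the higher of the two numbers measured. Compound 2 gives 14000 nM. Going by the values given here, the only step between them, a 2.0-fold lower number from compound 1 to compound 2 (0.30 log units; within the scatter), lies within the scatter, so the two compounds cannot be placed in any order on these numbers.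

Compound 3, `Cc1cc(-c2ccccc2)n(/C(N)=N/S(=O)(=O)c2cc(C)c(Cl)cc2SCc2ccccc2C(F)(F)F)n1`, has not been measured. It differs from compound 1 in one place: 2-(trifluoromethyl)phenyl in place of 4-methylphenyl on a saturated chain carbon bound to a sulfur. Among the compounds with values here, the single measured step, a 2.0-fold lower number from compound 1 to compound 2 (0.30 log units; within the scatter), concerns a hydrogen in place of a methyl on an aromatic carbon of the shared core and leaves the sulfur-bound chain untouched, so no measured step speaks to this change. Nothing here points to a shift beyond the scatter in either direction. For compound 3 the expected value is therefore 28000 nM, with a range from 8000 nM to 100000 nM. This estimate means a step of no change at the digits printed from compound 1 to compound 3 (within the scatter), which is expected to stay within the scatter.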

Compound 3, half-maximal inhibitory concentration: 25000 nM
Compound 3: middle estimate off by 1.1-fold (0.05 log units), on the high side; low and high end bracket the measured number.
By their numbers in this assay, from the lowest: compounds 2, 3 and 1 (each within the scatter of the next).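

Going by these compounds alone, this is the first measured look at the sulfur-bound chain, since the earlier step concerned only the shared core. In this assay, 2-(trifluoromethyl)phenyl, with 10 heavy atoms including 3 fluorine, stands in place of 4-methylphenyl, with 7 heavy atoms, on a saturated chain carbon bound to a sulfur, and the result is a 1.1-fold lower number from compound 1 to compound 3 (0.05 log units; within the scatter), so this pair cannot be put in any order. The swap therefore exchanges two quite different substituted phenyl groups without moving the number beyond the scatter, though this holds for this one pair only, and no supporting measurement is available to explain the result.

On these data alone, what remains open is whether this place stays as flat when the group on it differs more sharply, for example a phenyl ring carrying a carboxylic acid or an amine, or a longer chain such as 2-phenylethyl in place of the benzyl group. A single pair also cannot show whether any group at this place would give a number beyond the scatter in either direction.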